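The source may hold more compounds than are shown below. What is called first, only, known or untested is meant among the compounds shown, and "the series" means these compounds.

The study concerns four compounds and one read-out, an ADME assay on THP-1 cells (Homo sapiens) for cytotoxicity, read by flow cytometry and propidium iodide staining, with a stated time of 72 h; a lower number here means a stronger inhibitor, a higher number a weaker inhibitor. Compound 1 `COc1cccc(-c2cc(=O)c3cc(NC(C)=O)ccc3o2)c1` gives 10000 nM in this assay. Compound 2 `CC(=O)Nc1ccc2oc(-c3cccc(F)c3)cc(=O)c2c1` differs from compound 1 by fluoro in place of methoxy on an aromatic carbon. In this assay compound 2 reaches only a limit, > 125000 nM. The step of an at least 12-fold higher number from compound 1 to compound 2 (1.09 log units; beyond the scatter) is therefore bounded on one side by the limit of > 125000 nM in this assay, at which 1 of the 3 values shown sits.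

Compound 3 `COc1ccccc1-c1oc2ccc(N)cc2c(=O)c1OC` carries a different core from compound 1; the difference between the two cores is not broken down here. In this assay compound 3 gives 116000 nM, a higher number than compound 1.

Compound 4 `COc1c(-c2ccccc2F)oc2ccc(N)cc2c1=O` has not yet been measured. It differs from compound 3 by fluoro in place of methoxy on an aromatic carbon. The two places are not identical: in compound 1 the group sits meta to a large group, in compound 3 it sits ortho to a large group, so the change from compound 3 to compound 4 is the same kind of change as that from compound 1 to compound 2, not the same change. One step of this kind has been observed, an at least 12-fold higher number from compound 1 to compound 2 (1.09 log units; beyond the scatter), and it was large, although its full size is hidden behind (the limit of > 125000 nM in this assay, at which 1 of the 3 values shown sits). Compound 3 already gives a high number, 116000 nM.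

For the measured compounds named here, for compound 4 a step of a 2.2-fold higher number from compound 3 to compound 4 (0.33 log units; beyond the scatter) is expected, resting on the single measured step of an at least 12-fold higher number from compound 1 to compound 2 (1.09 log units; beyond the scatter). Compound 4 is therefore estimated at about 250000 nM, within a range of 90000 nM to 700000 nM, and it is quite possible that only a limit will be reported.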

Compound 4, half-maximal inhibitory concentration: > 125000 nM
Compound 4 gave a limit, no number; the forecaster's own chance of this, stated with the estimate: 60%; the middle value does not contradict the limit.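

Fluoro in place of methoxy on an aromatic carbon can now be read on a second core, and in this assay the step is an at least 1.0-fold higher number from compound 3 to compound 4 (0.03 log units; that floor lies within the scatter). This shows that neither core gives a lower number after the change, but the floor of the new step lies within the scatter, so it does not establish a rise on the core of compound 3, and setting the two steps side by side does not separate them: the same change on two cores in this assay, an at least 12-fold higher number (1.09 log units; beyond the scatter) from compound 1 to compound 2 and an at least 1.0-fold higher number (0.03 log units; that floor lies within the scatter) from compound 3 to compound 4; the limit leaves it open whether they differ Nor does it show whether the large step seen on the core of compound 1 carries over in full, in part or not at all, since both fluoro compounds end at a limit rather than a number: the limit of > 125000 nM in this assay, at which 2 of the 4 values shown sit.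

The compounds shown leave open whether a chloro, a methyl or a hydroxyl in place of the methoxy would give a number under the limit on either core, which would allow the steps to be sized and compared. They also leave open how the same change behaves with an amine or an acetamide swapped between the two cores, with everything else held constant.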